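A few compounds are considered here, and "the series" means these few. Any claim that something is new, unique, unknown or untested is made for them only; others in the source may bear on it.

Compound 1 `CCCSc1nc(N/N=C/c2ccc(Cl)cc2)c2nnn(Cc3ccccc3)c2n1`: in a functional assay on MGC-803 cells (Homo sapiens) for antiproliferative activity, read by MTT assay, with a stated time of 72 h (a higher number here means a weaker inhibitor, a lower number a stronger inhibitor), compound 1 gives > 64000 nM, which is a limit of the assay.
Compound 2 `CCCSc1nc(N/N=C/c2cccs2)c2nnn(Cc3ccccc3)c2n1`: in this assay compound 2 gives > 64000 nM, again only a limit.

Compound 2 therefore stands at a limit in this assay, and the step that the two limits leave unreadable from compound 1 to compound 2 cannot be read because of the limit of > 64000 nM in this assay, at which 2 of the 2 values shown sit. Compound 3 `CCCSc1nc(N/N=C/c2c[nH]c3ccccc23)c2nnn(Cc3ccccc3)c2n1` carries 1H-indol-3-yl in place of thiophen-2-yl on a carbon with a double bond to nitrogen. For the measured compounds named here, no readable measured step bears on this change; the single recorded step is unreadable. Compound 3 is thus expected to stay near the limit, with an expected step of an at least 1.6-fold lower number from compound 2 to compound 3 (0.20 log units; that floor lies within the scatter) and an estimated value of 40000 nM, in a range from 5000 nM to 100000 nM.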

Compound 3, half-maximal inhibitory concentration: 7410 nM
The estimate for compound 3 lay 5.4-fold (0.73 log units) above the measured number; the measured number falls inside the stated range.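

At this position, on a carbon with a double bond to nitrogen, 1H-indol-3-yl is the only group shown that gives a readable number in this assay, with an at least 8.6-fold lower number from compound 2 to compound 3 (0.93 log units; beyond the scatter) and an at least 8.6-fold lower number from compound 1 to compound 3 (0.93 log units; beyond the scatter). Both sizes are floors rather than measured gaps, because the other two compounds sit at a limit: the limit of > 64000 nM in this assay, at which 2 of the 3 values shown sit.

The step from compound 1 to compound 2 cannot be read, and the compounds shown leave open whether the change follows the added six-membered ring or the hydrogen-bond donor of 1H-indol-3-yl. A benzofuran-3-yl or a 1H-pyrrol-3-yl group at this position would separate the two.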